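Chloro placement on the benzyl arms of the cyclic sulfonylurea core

The source may hold more compounds than are shown below. What is called first, only, known or untested is meant among the compounds shown, and "the series" means these compounds.

Three compounds share one core and differ only in the chlorine carried by the two benzyl arms. Compound 3 `O=C1c2ccccc2N(Cc2ccccc2Cl)S(=O)(=O)N1Cc1ccccc1` has a 2-chlorobenzyl arm and a plain benzyl arm; compound 1 `O=C1c2ccccc2N(Cc2ccccc2Cl)S(=O)(=O)N1Cc1ccccc1Cl` carries two 2-chlorobenzyl arms; compound 2 `O=C1c2ccccc2N(Cc2ccccc2)S(=O)(=O)N1Cc1ccc(Cl)cc1` pairs a plain benzyl arm with a 4-chlorobenzyl arm. The difference between the cores of compound 2 and compound 3 is not broken down here.

In a functional assay on HEL cells (Homo sapiens) for inhibition (on this read-out higher numbers stand for lower toxicity in this test and lower numbers for higher toxicity in this test), compound 3 gives 88000 nM. Compound 2 gives 121000 nM in this assay, which lies within the scatter of compound 3, so no order between the two is claimed. Compound 1 gives > 200000 nM in this assay, which is a limit of the assay and not a number. That reading sits at the limit of > 200000 nM in this assay, at which 1 of the 3 values shown sits.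

The change chloro in place of hydrogen on an aromatic carbon gives an at least 2.2-fold higher number from compound 3 to compound 1 (0.35 log units; beyond the scatter). Compound 4 `O=C1c2ccccc2N(Cc2ccc(Cl)cc2)S(=O)(=O)N1Cc1ccc(Cl)cc1` is not yet measured; it arises from compound 2 by chloro in place of hydrogen on an aromatic carbon. This is the same kind of change, but the place differs: in compound 1 the chloro sits ortho to a large group, in compound 4 it sits para to a large group.

Because an at least 2.2-fold higher number from compound 3 to compound 1 (0.35 log units; beyond the scatter) moved the number upward, a step of similar direction is expected here, namely a 1.8-fold higher number from compound 2 to compound 4 (0.26 log units; within the scatter). Compound 4 is therefore estimated at 220000 nM in this assay, with the expected span from 100000 nM to 500000 nM. A limit reading for compound 4 is a real possibility.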

Compound 4, half-maximal cytotoxic concentration: > 200000 nM
Compound 4 ended at the assay's limit (the forecaster's own chance of this, stated with the estimate: 50%); the middle value does not contradict the limit.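

In this assay, chloro in place of hydrogen on an aromatic carbon, here para to a large group, gives an at least 1.6-fold higher number from compound 2 to compound 4 (0.21 log units; that floor lies within the scatter), so this step alone does not establish a rise beyond the scatter. Set beside the step on the other core, where the chloro sits ortho to a large group, the result supports only a loose statement that the change carries over, with no drop in the number seen on either core, and the two steps cannot be ranked by size: the same change on two cores in this assay, an at least 2.2-fold higher number (0.35 log units; beyond the scatter) from compound 3 to compound 1 and an at least 1.6-fold higher number (0.21 log units; that floor lies within the scatter) from compound 2 to compound 4; the limit leaves it open whether they differ. The carry-over of a step size from one core to another therefore remains unshown, and the transfer rests on just two pairs, with the upper compound of each pair reading as a limit of the assay and not as a number: the limit of > 200000 nM in this assay, at which 2 of the 4 values shown sit.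

Open, from the compounds shown here alone, is how the number responds when a benzyl arm carries a methoxy group, an amine or a carboxylic acid instead of chloro, or when a longer chain takes the place of a benzyl arm. Also open, going by these compounds, is how the two chloro placements compare on a single core, as each placement appears here on a different core.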